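Amino in place of phenethyloxy at the carbonyl of compound 1

The compounds below may be only part of what the source reports. "The series", "measured", "known", "first", "only" and "open" are said of these compounds alone.

Compound 1 `COc1ccc2c(c1)OC(c1cc(OC)c(OC)c(OC)c1)C(C(=O)OCCc1ccccc1)=C2` gives 16200 nM in a functional assay for inhibition of nuclear factor NF-kappa-B complex (Homo sapiens) (a higher number here means a weaker inhibitor, a lower number a stronger inhibitor), the second highest of three numbers. Compound 2 `CCOCC1=Cc2ccc(OC)cc2OC1c1cc(OC)c(OC)c(OC)c1` gives 21300 nM, and compound 3 `COc1ccc2c(c1)OC(c1cc(OC)c(OC)c(OC)c1)C(C(=O)OC(C)(C)C)=C2` gives 14100 nM; both sit within the scatter of compound 1, as the steps of a 1.3-fold higher number from compound 1 to compound 2 (0.12 log units; within the scatter) and a 1.1-fold lower number from compound 1 to compound 3 (0.06 log units; within the scatter) show, and the step of a 1.5-fold lower number from compound 2 to compound 3 (0.18 log units; within the scatter) is likewise within the scatter. Compound 4 `COc1ccc2c(c1)OC(c1cc(OC)c(OC)c(OC)c1)C(C(N)=O)=C2` differs from compound 1 in one place: amino in place of phenethyloxy on a carbonyl carbon, or, cut one bond further out, phenethyloxycarbonyl to carbamoyl. The measured steps that touch the same double-bonded ring carbon all stayed within the scatter, so no step beyond the scatter is expected here either, with the step of a 1.0-fold lower number from compound 1 to compound 4 (0.01 log units; within the scatter) meant as a flat one. Compound 4 is therefore estimated at 16000 nM, within 5000 nM to 50000 nM.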

Compound 4, half-maximal inhibitory concentration: > 50000 nM
Compound 4 ended at the assay's limit; the forecaster's own chance of this, stated with the estimate: 15%; at least 3.1-fold (0.49 log units) between middle value and limit.
By their numbers in this assay, from the lowest: compounds 3, 1 and 2 (each within the scatter of the next). At a limit, above all of these: compound 4.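

In this assay compound 4 gives a limit and not a number: the limit of > 50000 nM in this assay, at which 1 of the 4 values shown sits. Of the groups shown on the double-bonded ring carbon, carbamoyl alone gives steps beyond the scatter, namely an at least 3.0-fold higher number from compound 1 to compound 4 (0.48 log units; beyond the scatter), an at least 3.5-fold higher number from compound 3 to compound 4 (0.54 log units; beyond the scatter) and an at least 2.3-fold higher number from compound 2 to compound 4 (0.37 log units; beyond the scatter). The position therefore does respond to its substituent, although phenethyloxycarbonyl, tert-butoxycarbonyl and ethoxymethyl stayed within the scatter of one another.

Going by these compounds, how far compound 4 lies past its limit remains open. So does whether a carboxylic acid or an N-methyl amide on this carbonyl carbon would read like compound 4 or like the esters.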